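Oxadiazole substituent change in a fluoroquinolone series against A549 cells

A few compounds are considered here, and "the series" means these few. Any claim that something is new, unique, unknown or untested is made for them only; others in the source may bear on it.

Measured compounds:
compound 1, `CCn1cc(-c2nnc(COc3ccc4ccccc4c3)o2)c(=O)c2cc(F)c(N3CCNCC3)cc21`, 80.2 ug/mL
compound 2, `CCn1cc(-c2nnc(COc3cccc4ccccc34)o2)c(=O)c2cc(F)c(N3CCNCC3)cc21`, 127 ug/mL

Compound 2 stands highest of the two numbers in a functional assay on A549 cells (Homo sapiens) for cytotoxicity, read by MTT assay; on this read-out lower numbers stand for stronger inhibition and higher numbers for weaker inhibition; its nearest neighbour is compound 1, with a 1.6-fold higher number from compound 1 to compound 2 (0.20 log units; within the scatter). Compound 3, `CCn1cc(-c2nnc(-c3ccccc3)o2)c(=O)c2cc(F)c(N3CCNCC3)cc21`, is not yet measured. It differs from compound 2 in one place: phenyl in place of ((naphthalen-1-yl)oxy)methyl on an aromatic carbon. Within the data shown here, the only measured step, the one from compound 1 to compound 2, swaps the naphthyl attachment and stays within the scatter, so it does not speak to losing the ether-linked naphthyl altogether. Among the measured compounds shown here, no measured step bears on this change directly. With nothing to lean on, a step of no more than the scatter is expected, in either direction, as a 1.3-fold lower number from compound 2 to compound 3 (0.10 log units; within the scatter). For compound 3 the estimate is 100 ug/mL, in the range 40 ug/mL to 250 ug/mL.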

Compound 3, half-maximal inhibitory concentration: 112 ug/mL
Compound 3: the middle estimate sits 1.1-fold (0.05 log units) below what was measured; the range from low to high includes it.
By their numbers in this assay, from the lowest: compounds 1, 3 and 2 (each within the scatter of the next).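

In this assay, phenyl in place of ((naphthalen-1-yl)oxy)methyl on this aromatic carbon gives a 1.1-fold lower number from compound 2 to compound 3 (0.05 log units; within the scatter) and phenyl in place of ((naphthalen-2-yl)oxy)methyl gives a 1.4-fold higher number from compound 1 to compound 3 (0.15 log units; within the scatter) as the second step. The larger group with its ether oxygen and second aromatic ring can therefore go, from either naphthyl attachment, without a change beyond the scatter. Nothing measured here offers a reason for this.

The compounds shown leave open whether any group at this carbon moves the number beyond the scatter. An amine, a carboxylic acid or a longer chain here remains an open case.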